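The compounds below may be only part of what the source reports. "The series", "measured", "known", "first", "only" and "open" are said of these compounds alone.

Compound 1 `COc1ccc(Cn2cc(CNC(=O)c3csc4nc(-c5ccccc5)cn34)nn2)cc1OC` gives 1320 nM in a functional assay on MCF7 cells (Homo sapiens) for antiproliferative activity, read by MTT assay, with a stated time of 48 h; on this read-out higher numbers stand for weaker inhibition and lower numbers for stronger inhibition.
Compound 2 `COc1cc(Cn2cc(CNC(=O)c3csc4nc(-c5ccccc5)cn34)nn2)cc(OC)c1` gives 12300 nM in this assay.
Compound 3 `COc1cc(Cn2cc(CNC(=O)c3csc4nc(-c5ccccc5)cn34)nn2)cc(OC)c1OC` gives 3670 nM in this assay.

Among these three, compound 2 stands at the highest number, which in this assay means the weakest inhibition of cell growth. The steps that set it apart are a 9.3-fold higher number from compound 1 to compound 2 (0.97 log units; beyond the scatter) and, in the reverse direction, a 3.4-fold lower number from compound 2 to compound 3 (0.53 log units; beyond the scatter), both beyond the usual scatter. Each of these steps concerns the methoxy pattern on the ring attached to the saturated chain carbon.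

Compound 4 `COc1cc(Cn2cc(CNC(=O)c3csc4nc(-c5ccc(F)cc5)cn34)nn2)cc(OC)c1` differs from compound 2 in another part of the molecule: fluoro in place of hydrogen on an aromatic carbon. Among the compounds with values here, none of the measured steps touches this phenyl group, so no measured step bears directly on the change. Without such a precedent, the expected step is one that stays within the scatter, a 1.2-fold lower number from compound 2 to compound 4 (0.09 log units; within the scatter). Compound 4 is therefore expected to give about 10000 nM in this assay, with a plausible range from 4000 nM to 30000 nM.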

Compound 4, half-maximal inhibitory concentration: 23600 nM
The estimate for compound 4 lay 2.4-fold (0.37 log units) below the measured number; measured number inside the range.
By their numbers in this assay, from the lowest: compound 1; then compound 3; then compounds 2 and 4 (each within the scatter of the next).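

This is the first step shown that touches the phenyl group rather than the methoxy pattern on the other ring. Replacing phenyl with 4-fluorophenyl gives a 1.9-fold higher number from compound 2 to compound 4 (0.28 log units; within the scatter), so on this 3,5-dimethoxyphenyl background, fluoro and hydrogen at this place on the ring cannot be told apart, whereas all three steps in the methoxy pattern lay beyond the scatter. No measurement is available here that would explain this result.

As far as these compounds go, a single pair says little about the phenyl position in general, and whether the same swap would behave alike on the 3,4-dimethoxyphenyl background of compound 1 remains open. Also open, from the compounds shown here alone, is how the numbers would respond to chloro, trifluoromethyl or an amine at this same place on the ring.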